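The compounds below may be only part of what the source reports. "The series", "measured", "known", "first", "only" and "open" are said of these compounds alone.

Measured so far:
compound 1 `CCCCCON1C(=O)[C@@H](NC(=O)OCCCCC2CCCCC2)[C@@H]1C` gives 387 nM
compound 2 `C[C@H]1[C@H](NC(=O)OCCCCC2CCCCC2)C(=O)N1Oc1ccccc1` gives 23 nM

Both numbers come from an assay on HEK293 cells for inhibition of N-acylethanolamine-hydrolyzing acid amidase (Homo sapiens), read by fluorescence, with stated times of 10 min and 50 min; a higher number here means a weaker inhibitor, a lower number a stronger inhibitor. For the measured compounds named here, compound 2 stands lowest of the two, and the single measured step, a 17-fold lower number from compound 1 to compound 2 (1.23 log units; beyond the scatter), leads to it. Compound 3 `C[C@H]1[C@H](NC(=O)OCCCCC2CCCCC2)C(=O)N1Oc1ccccc1S(C)(=O)=O` differs from compound 2 by methylsulfonyl in place of hydrogen on an aromatic carbon. That one step swapped the whole group on the oxygen rather than altering the phenyl itself, so it bears only loosely on the present change, and no step beyond the scatter is expected in this assay: a 1.3-fold higher number from compound 2 to compound 3 (0.12 log units; within the scatter). Compound 3 is therefore estimated at 30 nM, with a range from 8 nM to 120 nM.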

Compound 3, half-maximal inhibitory concentration: 6 nM
For compound 3 the middle estimate is 5.0-fold (0.70 log units) above the measured one, outside the stated range (below it).
By their numbers in this assay, from the lowest: compound 3; then compound 2; then compound 1.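

Substituting the phenyl ring itself, and not only swapping the whole group on the oxygen, also changes the result: in this assay methylsulfonyl on this aromatic carbon, ortho to a large group, brings a 3.8-fold lower number from compound 2 to compound 3 (0.58 log units; beyond the scatter) and so a modest gain. Replacing pentyl with 2-(methylsulfonyl)phenyl brings a 65-fold lower number from compound 1 to compound 3 (1.81 log units; beyond the scatter) in all, a large gain. Nothing shown explains why the number falls. Still open, on these data alone, is whether methylsulfonyl elsewhere on the ring would give a similar step, and whether an amine or a carboxylic acid at this same carbon would also lower the number.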